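This account rests on a few compounds, and the source may have more. Where it says the series, first, only, none or still open, it means among the compounds named here.

Working notes on the series, values from a functional assay on SK-MEL-28 cells (Homo sapiens) for inhibition, read by MTT assay, with a stated time of 48 h (a higher number here means a weaker inhibitor, a lower number a stronger inhibitor), as follows:

- Compound 1 `Cc1ccc(-c2nc3ccccn3c2Sc2ccccc2)cc1`: > 100000 nM (a limit)
- Compound 2 `c1ccc(Sc2c(-c3ccccc3)nc3ccc(-c4ccccc4)cn23)cc1`: > 100000 nM (a limit)
- Compound 3 `Cc1ccc(-c2nc3ccc(C)cn3c2Sc2ccccc2)cc1`: 95700 nM

Compound 1 has no numerical value in this assay and stands only at the limit > 100000 nM of the assay. The data show the limit of > 100000 nM in this assay, at which 2 of the 3 values shown sit, and so give little resolution at this end of the range.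

The next compound is compound 4 `N#Cc1ccc(-c2nc3ccccn3c2Sc2ccccc2)cc1`, not yet measured. It differs from compound 1 by cyano in place of methyl on an aromatic carbon, para to a large group, that is 4-methylphenyl to 4-cyanophenyl: cyano in place of methyl on an aromatic carbon.

Going by the values given here, no measured step replaces this methyl. Among the compounds with values here, the only measured step bearing on compound 1 is methyl in place of hydrogen on an aromatic carbon, which leaves the 4-methylphenyl group untouched: an at least 1.0-fold lower number from compound 1 to compound 3 (0.01 log units; that floor lies within the scatter). It therefore gives no direction for the change to cyano, and no shift beyond the scatter is expected.

The expected step is an at least 1.1-fold lower number from compound 1 to compound 4 (0.04 log units; that floor lies within the scatter), and compound 4 may well also read only as a limit. For compound 4 the estimated value is 90000 nM, with an expected range from 40000 nM to 200000 nM in this assay.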

Compound 4, half-maximal inhibitory concentration: 67500 nM
Compound 4: middle estimate off by 1.3-fold (0.12 log units), on the high side; measured number inside the range.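

In this assay, going by these compounds alone, the change from 4-methylphenyl to 4-cyanophenyl is the first measured step that replaces this methyl, and it reads as an at least 1.4-fold lower number from compound 1 to compound 4 (0.17 log units; that floor lies within the scatter). The place para to a large group on this aromatic ring can therefore carry cyano and yield a numerical reading where compound 1 gave only a limit, although the printed floor of the step does not establish a shift beyond the scatter. The true size of the step cannot be read, since one end of it is only a limit and the assay offers little resolution at this end of the range: the limit of > 100000 nM in this assay, at which 2 of the 4 values shown sit.

The compounds shown leave open whether an amine, a carboxylic acid, a methoxy group or a longer chain in place of the cyano would take the reading clearly away from this weak end of the range. They also leave open whether cyano at this place and the added methyl of compound 3 would act independently when carried together on the shared core.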